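Replacing 6-methylpyridin-3-yl with cyclopropyl on the amide

The source may report more compounds than this note shows. Statements on the series, on what has been measured and on what is new or still open speak of the compounds shown alone.

Values measured in an in vitro ADME assay on microsomes from liver (Homo sapiens) for pharmacokinetics, read by LC-MS, with a stated time of 10 min, tested at 1 uM; on this read-out higher numbers stand for fast clearance and lower numbers for slow clearance:
- compound 1 `CN1C[C@H](C(=O)Nc2cccnc2)[C@@H](c2ccc(/C=C/C(=O)Nc3ccccc3N)cc2)C1` gives 10 mL/min/kg
- compound 2 `Cc1ccc(NC(=O)[C@H]2CN(C)C[C@@H]2c2ccc(/C=C/C(=O)Nc3ccccc3N)cc2)cn1` gives 8 mL/min/kg

Compound 2 lies within the scatter of compound 1 in this assay. Compound 3 `CN1C[C@H](C(=O)NC2CC2)[C@@H](c2ccc(/C=C/C(=O)Nc3ccccc3N)cc2)C1` carries cyclopropyl in place of 6-methylpyridin-3-yl on an amide-type nitrogen. Within the data shown here, only one measured step bears on this change. That step, a 1.3-fold lower number from compound 1 to compound 2 (0.10 log units; within the scatter), stays within the scatter, but it only adds methyl on an aromatic carbon and does not show what removing the aromatic group does. No shift beyond the scatter is therefore expected, and the estimated step is no change at the digits printed from compound 2 to compound 3 (within the scatter). Compound 3 is expected at 8 mL/min/kg, within an estimated range of 4 mL/min/kg to 16 mL/min/kg.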

Compound 3, clearance: 10 mL/min/kg
Estimate against measurement, compound 3: 1.3-fold (0.10 log units) below, and the stated range covers the measured number.
By their numbers in this assay, from the lowest: compounds 2, 1 and 3 (each within the scatter of the next).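

In this assay, cyclopropyl in place of 6-methylpyridin-3-yl on the amide-type nitrogen gives a 1.3-fold higher number from compound 2 to compound 3 (0.10 log units; within the scatter) and cyclopropyl in place of pyridin-3-yl gives no change at the digits printed from compound 1 to compound 3 (within the scatter) and both steps lie within the scatter. The aromatic ring at this position can therefore be replaced by a small non-aromatic ring of carbon only with no shift beyond the scatter, which the methyl step could not show. Nothing available explains this result. As far as these compounds go, whether an amine, a carboxylic acid or a longer chain on this nitrogen would move the read-out beyond the scatter remains open.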